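Replacing a Trifluoromethylphenyl Group on the Ring Nitrogen

The source may report more compounds than this note shows. Statements on the series, on what has been measured and on what is new or still open speak of the compounds shown alone.

Three compounds share one core and differ only in the aromatic group attached to an amine nitrogen in a six-membered non-aromatic ring with two nitrogen. Compound 1 `CCCc1nc(-c2ccccc2)c(CNCCCN2CCN(c3cccc(OC)c3)CC2)o1` carries a 3-methoxyphenyl there; in an assay on HEK293 cells for inhibition of Voltage-dependent T-type calcium channel subunit alpha-1G (Homo sapiens), read by fluorescence, tested at 10 uM (on this read-out lower numbers stand for less inhibition and higher numbers for more inhibition at the one concentration tested (going by the name of the read-out)), compound 1 gives 36.4%. Compound 2 `CCCc1nc(-c2ccccc2)c(CNCCCN2CCN(c3ccc(C(F)(F)F)cc3)CC2)o1` carries a 4-(trifluoromethyl)phenyl and gives 51.6%, a step of a number 15.2 percentage points higher from compound 1 to compound 2 (beyond the scatter). Compound 3 `CCCc1nc(-c2ccccc2)c(CNCCCN2CCN(c3ccccc3C(F)(F)F)CC2)o1` carries a 2-(trifluoromethyl)phenyl and gives 45%; the step of a number 6.6 percentage points lower from compound 2 to compound 3 (within the scatter) and the step of a number 8.6 percentage points higher from compound 1 to compound 3 (within the scatter) are both small, so compound 3 cannot be told apart from either neighbour with confidence.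

Within the data shown here, compound 4 `CCCc1nc(-c2ccccc2)c(CNCCCN2CCN(c3cccc(C)c3C)CC2)o1` keeps the whole core and changes only that aromatic group: 2,3-dimethylphenyl in place of 2-(trifluoromethyl)phenyl on an amine nitrogen in a ring. Among the measured compounds shown here, no measured step swaps a trifluoromethylphenyl for a dimethylphenyl, so the nearest guides are the two steps that touch compound 3, both within the scatter, and the one modest step from compound 1 to compound 2. Across all three measured aromatic groups the inhibition stays in a narrow band, so the step of no change at the digits printed from compound 3 to compound 4 (within the scatter) is expected to stay within the scatter. Compound 4 is therefore estimated at 45%, with a range from 30% to 60%.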

Compound 4, a percentage reported as inhibition, at one concentration (the size of the read-out at that concentration, not a potency): 55.2%
For compound 4 the middle estimate is 10.2 percentage points below the measured one; the measured number falls inside the stated range.
By their numbers in this assay, from the lowest: compounds 1, 3, 2 and 4 (each within the scatter of the next, the first and the last beyond it).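

In this assay, among these compounds, this position accepts a group with no fluorine at all: 2,3-dimethylphenyl in place of 2-(trifluoromethyl)phenyl gives a number 10.2 percentage points higher from compound 3 to compound 4 (beyond the scatter) and is the first step touching compound 3 that clears the scatter, so a trifluoromethyl group is not required here for this level of inhibition. The change to 2,3-dimethylphenyl from 4-(trifluoromethyl)phenyl gives a number 3.6 percentage points higher from compound 2 to compound 4 (within the scatter) and so cannot be told apart, which means two different aromatic groups sit together at this end of the series. The step from the 3-methoxyphenyl gives a number 18.8 percentage points higher from compound 1 to compound 4 (beyond the scatter) and, with compound 2 also clear of compound 1, sets the 3-methoxyphenyl apart from those two groups, although compound 3 goes against this by staying within the scatter of compound 1; nothing available explains these differences.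

On these data alone, whether one methyl alone, as in a 2-methylphenyl or a 3-methylphenyl, would match the two methyl groups together stays open, and so does the result for a 2,3-dichlorophenyl. Since every number comes from a single concentration, the compounds shown also leave open how their potencies would compare across a range of concentrations.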